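A dimethylphenyl group replaces fluorophenyl on the sulfur

The source may report more compounds than this note shows. Statements on the series, on what has been measured and on what is new or still open speak of the compounds shown alone.

Three compounds sharing one core are on record for a functional assay on A549 cells (Homo sapiens) for antiproliferative activity, read by CCK-8 assay, with a stated time of 72 h (on this read-out lower numbers stand for stronger inhibition and higher numbers for weaker inhibition), and only one of them has a number. In this assay compound 1 (`CCc1ccc(SCc2ccc(C(=O)Nc3ccccc3N)cc2)cc1`) gives 3040 nM and no other figure is available. For compound 2 (`Nc1ccccc1NC(=O)c1ccc(CSc2cccc(F)c2)cc1`) the entry reads "not determined" (no result reported) and for compound 3 (`Nc1ccccc1NC(=O)c1ccc(CSc2ccc(F)cc2)cc1`) it reads "not determined" (no result reported) as well. Compound 3 therefore has no place on the scale, and compound 2 shares that gap.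

Compound 4 (`Cc1cc(C)cc(SCc2ccc(C(=O)Nc3ccccc3N)cc2)c1`) differs from compound 3 by a single exchange, 3,5-dimethylphenyl in place of 4-fluorophenyl on a sulfur with the rest of the structure unchanged. Among the compounds with values here, without a number for compound 3, this exchange cannot be sized directly, and no measured step between related compounds is available as a guide. Within the data shown here, the only anchor is compound 1 at 3040 nM as a reference point, a compound that also differs from compound 4 only in the group on the sulfur. A shift from that value beyond the usual scatter is not expected in this assay in either direction, although this rests on one number alone. Compound 4 is expected at an estimated 3000 nM with a likely range from 1000 nM to 9000 nM in this estimate.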

Compound 4, half-maximal inhibitory concentration: 2890 nM
For compound 4 the middle estimate is 1.0-fold (0.02 log units) above the measured one; measured number inside the range.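

In this assay, the exchange of 4-ethylphenyl for 3,5-dimethylphenyl on the sulfur gives a 1.1-fold lower number from compound 1 to compound 4 (0.02 log units; within the scatter), so these two groups cannot be told apart on this read-out. Within the data shown here, this is the first comparison at this position, and it shows that the number stays within the scatter when one carbon-only aromatic ring bearing small hydrocarbon groups replaces another; the two compounds do not establish a trend beyond this pair. Nothing on hand accounts for this result or links it to any property of the two groups.

As far as these compounds go, the steps to compound 4 from compound 2 and compound 3 cannot be read, as neither of these fluorophenyl compounds has a single number, and the size of the exchange of 4-fluorophenyl for 3,5-dimethylphenyl remains unknown. The compounds shown also leave open how this read-out would respond if the aromatic ring on the sulfur carried an amine or a carboxylic acid, or if a longer chain took the place of the ethyl group.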